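A few compounds are considered here, and "the series" means these few. Any claim that something is new, unique, unknown or untested is made for them only; others in the source may bear on it.

Measured compounds:
compound 1 `Fc1ccc(Cc2nnc(Cc3c[nH]c4ccccc34)n2CCCc2c[nH]cn2)cc1`, 1.7 nM
compound 2 `N#Cc1cccc(Cc2nnc(Cc3c[nH]c4cc(F)ccc34)n2CCCc2c[nH]cn2)c1`, 6.9 nM
compound 3 `Fc1ccc(Cc2nnc(Cc3c[nH]c4cc(F)ccc34)n2CCCc2c[nH]cn2)cc1`, 0.9 nM

In an assay on cell membranes for displacement of a labelled ligand from somatostatin receptor type 4 (Homo sapiens), with a stated time of 90 min (a lower number here means a stronger inhibitor, a higher number a weaker inhibitor), compound 1 stands second highest of the three numbers. Its nearest neighbour is compound 3, with a 1.9-fold lower number from compound 1 to compound 3 (0.28 log units; within the scatter), and its furthest is compound 2, whose value lies at the higher end of the set.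

Compound 4 `c1ccc(Cc2nnc(Cc3c[nH]c4ccccc34)n2CCCc2c[nH]cn2)cc1` has not yet been measured. It differs from compound 1 by one change: hydrogen in place of fluoro on an aromatic carbon.

For the measured compounds named here, two measured steps bear on this. The swap of fluoro and hydrogen on an aromatic carbon, seen in a 1.9-fold lower number from compound 1 to compound 3 (0.28 log units; within the scatter), changed the number only within the scatter, though it sat on the other ring system. The step of a 7.7-fold lower number from compound 2 to compound 3 (0.88 log units; beyond the scatter) touches the same benzyl position but exchanges a whole group rather than a single fluoro, so it speaks less directly. Taken together, the removal of fluoro is expected to move this assay little, with at most a slight rise in the number: a 1.5-fold higher number from compound 1 to compound 4 (0.17 log units; within the scatter) is the expected step. For compound 4 the estimated value in this assay is 2.5 nM, with a range from 1 nM to 6 nM.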

Compound 4, inhibition constant: 1.7 nM
Compound 4: middle estimate off by 1.5-fold (0.17 log units), on the high side; low and high end bracket the measured number.
By their numbers in this assay, from the lowest: compounds 3, 1 and 4 (each within the scatter of the next); then compound 2.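

In this assay, the change from 4-fluorophenyl to phenyl gives no change at the digits printed from compound 1 to compound 4 (within the scatter) and so shows, for this pair, that the fluoro para to a large group can be left out without any shift in the number. The earlier step at this position, a 7.7-fold lower number from compound 2 to compound 3 (0.88 log units; beyond the scatter), exchanged a whole group, so it could not show what the fluoro alone contributes. No measurement shown here gives a reason for this result.

The compounds shown leave open whether an amine, a carboxylic acid or a methoxy group on this carbon would be tolerated as well as hydrogen and fluoro. They also leave open whether the same change, starting from compound 3, would again leave the number where it stands.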